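The source may report more compounds than this note shows. Statements on the series, on what has been measured and on what is new or still open speak of the compounds shown alone.

Compound 1 `COc1cc(-c2oc3ccccc3c(=O)c2C(=O)O)cc(OC)c1OC`, compound 2 `COc1cc(OC)cc(-c2oc3ccccc3c(=O)c2C(=O)O)c1` and compound 3 `O=C(O)c1c(-c2ccc([N+](=O)[O-])cc2)oc2ccccc2c1=O` were all tested in a functional assay on SK-MEL cells (Homo sapiens) for cytotoxicity, read by MTT assay, with a stated time of 6 days; on this read-out lower numbers stand for an effect already at smaller amounts and higher numbers for an effect only at larger amounts of compound. In this assay compound 1 reaches only the limit > 25 ug/mL. Compound 2 likewise gives only the limit > 25 ug/mL. Compound 3 also stops at the limit > 25 ug/mL. Compound 1 differs from compound 2 by methoxy in place of hydrogen on an aromatic carbon, and the step that the two limits leave unreadable from compound 2 to compound 1 cannot be sized because of the limit of > 25 ug/mL in this assay, at which 3 of the 3 values shown sit. The difference between the cores of compound 2 and compound 3 is not broken down here. Compound 4 `COc1ccc2oc(-c3ccc([N+](=O)[O-])cc3)c(C(=O)O)c(=O)c2c1` differs from compound 3 by methoxy in place of hydrogen on an aromatic carbon, the same kind of change but at a different place: meta and para to a fused ring rather than ortho to two methoxy groups and para to a large group. Among the measured compounds shown here, with the only comparable step unreadable, the expected step is a step that the limit leaves unreadable from compound 3 to compound 4. For compound 4 this gives an estimate of 30 ug/mL, most probably again only a limit.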

Compound 4, concentration for half-maximal effect: > 25 ug/mL
Compound 4: no number, only a limit; the forecaster's own chance of this, stated with the estimate: 80%; the middle value is on the limit's open side.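

The step from compound 3 to compound 4 cannot be read, because both compounds give only a limit: the limit of > 25 ug/mL in this assay, at which 4 of the 4 values shown sit. Going by these compounds, how far methoxy in place of hydrogen shifts the effect in this assay stays open, as does how these compounds rank.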